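A Hydroxy Group Added to the Sugar Ring

A few compounds are considered here, and "the series" means these few. Any claim that something is new, unique, unknown or untested is made for them only; others in the source may bear on it.

Compound 1 `Nc1ncnn2c([C@@H]3O[C@H](CO)[C@@H](O)[C@H]3O)cc(Br)c12` in an ADME assay on cells (Macrophage, Mus musculus) for cytotoxicity (on this read-out higher numbers stand for lower toxicity in this test and lower numbers for higher toxicity in this test), gives 2000 nM.
Compound 2 `Nc1ncnn2c([C@@H]3O[C@H](CO)[C@@H](O)[C@H]3O)ccc12` gives only a limit of the assay in this assay, namely < 250 nM.
Compound 3 `Nc1ncnn2c([C@@H]3O[C@H](CO)C[C@H]3O)cc(-c3ccc(Cl)cc3)c12` gives 24000 nM in this assay.

Compound 3 has the highest of the two numbers shown; compound 1 is nearest, and the gap between them is beyond the usual scatter. Compound 4 `Nc1ncnn2c([C@@H]3O[C@H](CO)[C@@H](O)[C@H]3O)cc(-c3ccc(Cl)cc3)c12` is not yet measured and differs from compound 3 in one place: hydroxy in place of hydrogen on a saturated ring carbon. Going by the values given here, the only measured step, an at least 8.0-fold lower number from compound 1 to compound 2 (0.90 log units; beyond the scatter), changes a group on an aromatic carbon rather than on the saturated ring, so no measured step bears directly on this change. With no guide of that kind, no step beyond the scatter is expected here. Compound 4 is therefore estimated at 15000 nM, within 4000 nM to 40000 nM. The expected step is a 1.6-fold lower number from compound 3 to compound 4 (0.20 log units; within the scatter).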

Compound 4, half-maximal cytotoxic concentration: 5000 nM
The estimate for compound 4 lay 3.0-fold (0.48 log units) above the measured number; the range from low to high includes it.
By their numbers in this assay, from the lowest: compound 1; then compound 4; then compound 3. At a limit, below all of these: compound 2.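

Going by these compounds alone, the hydroxy on this saturated ring carbon is the first change at the sugar ring to be measured, and it counts in this assay, with a 4.8-fold lower number from compound 3 to compound 4 (0.68 log units; beyond the scatter). On the aromatic carbon, 4-chlorophenyl gives a higher number than either bromo or hydrogen, with a 2.5-fold higher number from compound 1 to compound 4 (0.40 log units; beyond the scatter) and an at least 20-fold higher number from compound 2 to compound 4 (1.30 log units; beyond the scatter). Compound 2 gives only a limit, so that last step has no exact size: the limit of < 250 nM in this assay, at which 1 of the 4 values shown sits.

The compounds shown compare only hydrogen and hydroxy on this ring carbon, leaving open how an amine or a methoxy group there would read. Also open, on these data alone, is whether the hydroxy step keeps its size with bromo in place of 4-chlorophenyl.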